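Diaryl urea series: 3,4-dichlorophenyl urea expectation

The source may report more compounds than this note shows. Statements on the series, on what has been measured and on what is new or still open speak of the compounds shown alone.

Compound 2 `COc1cc2cc(Oc3ccc(NC(=O)Nc4ccc(Cl)c(C(F)(F)F)c4)cc3)c(C)nc2cc1OC` gives 2.59% in a functional assay on MCF7 cells (Homo sapiens) for inhibition, read by sulforhodamine B assay, with a stated time of 48 h, tested at 10 uM (a lower number here means a stronger effect, a higher number a weaker effect of the compound at the concentration tested), the lowest of the two values measured. Compound 1 `COc1cc2cc(Oc3ccc(NC(=O)Nc4ccc(C(F)(F)F)cc4)cc3)c(C)nc2cc1OC` gives 84.3% in this assay. Compound 3 `COc1cc2cc(Oc3ccc(NC(=O)Nc4ccc(Cl)c(Cl)c4)cc3)c(C)nc2cc1OC` differs from compound 2 by chloro in place of trifluoromethyl on an aromatic carbon. Among the compounds with values here, the only measured step is a number 81.7 percentage points lower from compound 1 to compound 2 (beyond the scatter), which changed the same aromatic ring and was large. Within the data shown here, no measured step separates chloro from trifluoromethyl at this place, so the direction is uncertain; a step of a number 17.4 percentage points higher from compound 2 to compound 3 (beyond the scatter) is expected, weaker than compound 2 but still well below compound 1. Compound 3 is estimated at 20%, with a range of 2% to 65%.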

Compound 3, a percentage reported as activity, at one concentration (the size of the read-out at that concentration, not a potency): 13.8%
Compound 3: middle estimate off by 6.2 percentage points, on the high side; measured number inside the range.
By their numbers in this assay, from the lowest: compound 2; then compound 3; then compound 1.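

In this assay, chloro in place of trifluoromethyl on the aromatic carbon ortho to a chloro group gives a number 11.2 percentage points higher from compound 2 to compound 3 (beyond the scatter) as a modest step, so trifluoromethyl holds a measurable edge at this place. Both substituents remain far ahead of the parent, and a number 70.5 percentage points lower from compound 1 to compound 3 (beyond the scatter) shows that 3,4-dichlorophenyl keeps most of the large gain over 4-(trifluoromethyl)phenyl. No evidence here explains the difference between chloro and trifluoromethyl.

Still open, as far as these compounds go, is whether a non-halogen group at this place, such as methoxy, nitrile or an amine, would retain the effect. The compounds shown also leave open how far a single chloro at this place would go without the second substituent.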